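This account rests on a few compounds, and the source may have more. Where it says the series, first, only, none or still open, it means among the compounds named here.

Measured compounds:
Compound 1 `Cc1nc(-c2cccnc2)sc1-c1nnc(-c2ccc(Br)cc2)o1` gives > 100 ug/mL in an ADME assay on HeLa cells (Homo sapiens) for cytotoxicity, read by MTT assay; on this read-out lower numbers stand for higher toxicity in this test and higher numbers for lower toxicity in this test.
Compound 2 `Cc1nc(-c2cccnc2)sc1-c1nnc(-c2ccccc2)o1` gives > 100 ug/mL in this assay.
Compound 3 `Cc1ccc(-c2nnc(-c3sc(-c4cccnc4)nc3C)o2)cc1` gives > 100 ug/mL in this assay.

Each of these values is a limit of the assay rather than a number, as shown by the limit of > 100 ug/mL in this assay, at which 3 of the 3 values shown sit, and compound 3 therefore stands at that limit together with the other two. The steps a step that the two limits leave unreadable from compound 1 to compound 2, a step that the two limits leave unreadable from compound 1 to compound 3 and a step that the two limits leave unreadable from compound 2 to compound 3 have no readable size, as both ends of each are limits.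

Compound 4 `Cc1nc(-c2cccnc2)sc1-c1nnc(-c2ccncc2)o1` differs from compound 3 by pyridin-4-yl in place of 4-methylphenyl on an aromatic carbon. The three measured steps all touch the same ring, yet none can be sized, so no shift beyond the scatter can be foreseen in this assay. The expected step is a step that the limit leaves unreadable from compound 3 to compound 4. Compound 4 is therefore estimated at 200 ug/mL, with a range from 80 ug/mL to 500 ug/mL, most likely again reported only as a limit.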

Compound 4, half-maximal cytotoxic concentration: > 100 ug/mL
Compound 4 gave a limit, no number; the forecaster's own chance of this, stated with the estimate: 85%; the middle value does not contradict the limit.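

No step can be sized between compound 4 and compounds 1, 2 and 3, because each value in this assay is a limit: the limit of > 100 ug/mL in this assay, at which 4 of the 4 values shown sit.

On these data alone, whether swapping these groups changes the read-out in this assay at all stays open.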